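This account rests on a few compounds, and the source may have more. Where it says the series, first, only, none or still open, it means among the compounds named here.

In an ADME assay on HEK-293T cells (Homo sapiens) for cytotoxicity, read by MTT assay, with a stated time of 3 days (on this read-out higher numbers stand for lower toxicity in this test and lower numbers for higher toxicity in this test), compound 1 (`CC(C)(C)NC(=O)COC(=O)c1ccc([N+](=O)[O-])o1`) gives > 100000 nM, which is a limit of the assay and not a number. Compound 2 (`CCC(C)(C)NC(=O)COC(=O)c1ccc([N+](=O)[O-])o1`) gives > 100000 nM, again only a limit. For the measured compounds named here, the one measured step, a step that the two limits leave unreadable from compound 1 to compound 2, therefore has no size to carry forward. Going by the values given here, compound 3 (`CC(C)(C)N(CCC(=O)c1ccccc1)C(=O)COC(=O)c1ccc([N+](=O)[O-])o1`) is recorded as "not active" (no number reported), so it stands without a single number, and the only other readings beside it are the limit of > 100000 nM in this assay, at which 2 of the 3 values shown sit.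

Compound 4 (`CC(C)(C)N(Cc1ccc(C(F)(F)F)cc1)C(=O)COC(=O)c1ccc([N+](=O)[O-])o1`) carries 4-(trifluoromethyl)phenyl in place of benzoylmethyl on a saturated chain carbon bound to an amide-type nitrogen. The measured step bears on this only weakly, since it concerns a methyl in place of hydrogen at a different place and yields no size. With no number for compound 3 as a starting point, no step beyond the usual scatter is expected in this assay, and no direction can be argued. The expectation that the reading stays close to the assay limit rests on compound 2, whose > 100000 nM is a limit. Compound 4 is estimated at 80000 nM, with an expected range of 25000 nM to 200000 nM.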

Compound 4, half-maximal cytotoxic concentration: 36000 nM
For compound 4 the middle estimate is 2.2-fold (0.35 log units) above the measured one; low and high end bracket the measured number.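

No new step can be read between compound 3 and compound 4: compound 3 carries no number, so the exchange of benzoylmethyl for 4-(trifluoromethyl)phenyl has no size. For the compounds shown here, compound 4 holds the only number, the other readings being limits or unnumbered: the limit of > 100000 nM in this assay, at which 2 of the 4 values shown sit. Left open is which part of the group on the amide-type nitrogen goes with the numerical reading of compound 4.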